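The compounds below may be only part of what the source reports. "The series", "measured", "known", "first", "only" and "open" are said of these compounds alone.

Measured compounds in a functional assay on the whole organism (Tail, strain ICR) with Mus musculus as the target, in the tail flick test, with a stated time of 120 min, at a dose of 25 umol/kg by the oral route; on this read-out higher numbers stand for a stronger effect at the one dose given and lower numbers for a weaker effect:
compound 1, `O=C(CN(c1nc(Cl)nc2[nH]cnc12)C1CC1)N[C@@H](CC(=O)OCc1ccccc1)C(=O)OCc1ccccc1`; compound 1 gives 12.1%.
compound 2, `CC[C@H](C)[C@H](NC(=O)CN(c1nc(Cl)nc2[nH]cnc12)C1CC1)C(=O)OCc1ccccc1`; compound 2 gives 22%.
compound 3, `O=C(CN(c1nc(Cl)nc2[nH]cnc12)C1CC1)NCC(=O)OCc1ccccc1`; compound 3 gives 21.7%.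

Compound 3 stands second highest of the three numbers. Its nearest neighbour is compound 2, separated by a number 0.3 percentage points lower from compound 2 to compound 3 (within the scatter), and its furthest is compound 1, separated by a number 9.6 percentage points higher from compound 1 to compound 3 (within the scatter); both gaps lie within the scatter, so no order among the three compounds can be claimed.

Compound 4, `C[C@H](NC(=O)CN(c1nc(Cl)nc2[nH]cnc12)C1CC1)C(=O)OCc1ccccc1`, differs from compound 3 in one place: methyl in place of hydrogen on a saturated chain carbon bound to an amide-type nitrogen and a carbonyl carbon. Within the data shown here, the steps that bear on this change are those at the same carbon: a number 0.3 percentage points lower from compound 2 to compound 3 (within the scatter), a number 9.6 percentage points higher from compound 1 to compound 3 (within the scatter) and, between the other two substituents, a number 9.9 percentage points higher from compound 1 to compound 2 (within the scatter). All three are within the scatter. Hydrogen, sec-butyl and (benzyloxycarbonyl)methyl at this carbon thus give numbers in this assay that cannot be told apart, and a methyl entering there is expected to behave the same way: the step of a number 0.7 percentage points lower from compound 3 to compound 4 (within the scatter) is expected to stay within the scatter, with no direction to be read from it. Compound 4 is therefore estimated at 21% in this assay, with a range from 11% to 31%.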

Compound 4, a percentage reported as activity, at one dose (the size of the read-out at that dose, not a potency): 36.1%
The estimate for compound 4 lay 15.1 percentage points below the measured number, and the stated range ends below it.
By their numbers in this assay, from the lowest: compounds 1, 3 and 2 (each within the scatter of the next); then compound 4.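

Methyl in place of hydrogen gives a number 14.4 percentage points higher from compound 3 to compound 4 (beyond the scatter) and methyl in place of sec-butyl gives a number 14.1 percentage points higher from compound 2 to compound 4 (beyond the scatter) in this assay so this saturated chain carbon does respond to its substituent, and methyl stands apart from both of those groups. The number does not rise steadily from hydrogen through methyl to sec-butyl, as compound 2 and compound 3 remain within the scatter of each other while compound 4 lies beyond it, and the comparison with the compound carrying the longer ester side chain gives a number 24 percentage points higher from compound 1 to compound 4 (beyond the scatter) as the largest step in the set. No measurement at hand bears on the reason for this result.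

Ethyl or isopropyl at this carbon would show whether the higher number belongs to methyl alone or extends to other small chains, since the groups shown run from methyl directly to sec-butyl. Also open are the mirror-image configuration at the methyl-bearing carbon and the replacement of the benzyl ester by a free carboxylic acid or a primary amide, as every compound shown keeps that ester.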